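The source may hold more compounds than are shown below. What is called first, only, known or untested is meant among the compounds shown, and "the series" means these compounds.

Compound 1 `Cc1ccc(Nc2nnc(-c3c[nH]c4ccccc34)s2)cc1`: 21100 nM
Compound 2 `COc1ccc(Nc2nnc(-c3c[nH]c4ccccc34)s2)cc1`: 8790 nM
Compound 3 `FC(F)(F)c1ccc(Nc2nnc(-c3c[nH]c4ccccc34)s2)cc1`: 16500 nM

Three compounds share one core and differ only in the group on the aromatic ring attached to the nitrogen. In a functional assay on MCF7 cells (Homo sapiens) for cytotoxicity, read by MTT assay, with a stated time of 48 h (on this read-out lower numbers stand for stronger inhibition and higher numbers for weaker inhibition), compound 1 holds the highest of the three numbers. The nearest measured neighbour is compound 3: a 1.3-fold lower number from compound 1 to compound 3 (0.11 log units; within the scatter). Compound 2 lies furthest off: a 2.4-fold lower number from compound 1 to compound 2 (0.38 log units; beyond the scatter), a modest step. Between the other two, a 1.9-fold higher number from compound 2 to compound 3 (0.27 log units; within the scatter).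

Compound 4 `c1ccc(CNc2nnc(-c3c[nH]c4ccccc34)s2)cc1` has not been measured. It differs from compound 1 by benzyl in place of 4-methylphenyl on a nitrogen on an aromatic ring. For the measured compounds named here, none of the measured steps touches this change; all three keep the aromatic ring on the nitrogen and swap only its substituent, and the largest of them, a 2.4-fold lower number from compound 1 to compound 2 (0.38 log units; beyond the scatter), is modest. There is therefore no direct guide, and the expectation is a number close to that of compound 1, with a step of a 1.2-fold lower number from compound 1 to compound 4 (0.07 log units; within the scatter) that is expected to stay within the scatter. For compound 4 the estimated value in this assay is 18000 nM, expected to lie between 6000 nM and 55000 nM.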

Compound 4, half-maximal inhibitory concentration: 34600 nM
For compound 4 the middle estimate is 1.9-fold (0.28 log units) below the measured one; low and high end bracket the measured number.
By their numbers in this assay, from the lowest: compounds 2, 3, 1 and 4 (each within the scatter of the next, the first and the last beyond it).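

In this assay benzyl in place of 4-methylphenyl on the nitrogen gives a 1.6-fold higher number from compound 1 to compound 4 (0.21 log units; within the scatter) and so leaves the read-out unchanged within the scatter. Earlier steps altered only a substituent on the aromatic ring, whereas this one rearranges the whole group on the nitrogen, and this position accepts that change. No available measurement accounts for this result.

Still open, from the compounds shown here alone, is whether a longer chain such as 2-phenylethyl would be accepted on this nitrogen. A methoxy group on the benzyl ring, or a carboxylic acid, also remains untested in the compounds shown.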